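Thiophene for pyridine on the shared core: cytotoxicity notes

The compounds below may be only part of what the source reports. "The series", "measured", "known", "first", "only" and "open" are said of these compounds alone.

Compound 1 `Oc1cccc(-c2cc(-c3cccnc3)nc(-c3ccccc3Cl)c2)c1` has a result of "not determined" (no result reported) in a functional assay on HCT-15 cells (Homo sapiens) for cytotoxicity, read by CCK-8 assay and cell counting, with a stated time of 2 days; on this read-out lower numbers stand for stronger inhibition and higher numbers for weaker inhibition. Among the compounds with values here, compound 2 `Oc1cccc(-c2cc(-c3ccc(Cl)cc3)nc(-c3cccnc3)c2)c1` is the only entry with a number: in this assay compound 2 gives 16800 nM, so it stands alone as the sole reference point. Compound 3 `Oc1cccc(-c2cc(-c3ccc(Cl)cc3)nc(-c3ccsc3)c2)c1` differs from compound 2 by thiophen-3-yl in place of pyridin-3-yl on an aromatic carbon. Within the data shown here, no measured step of this kind exists, so the expected step of a 1.1-fold lower number from compound 2 to compound 3 (0.05 log units; within the scatter) is put at none beyond the usual scatter, with no direction preferred. Compound 3 is therefore estimated at 15000 nM in this assay, within a range of 5000 nM to 45000 nM.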

Compound 3, half-maximal inhibitory concentration: 8850 nM
Compound 3: middle estimate off by 1.7-fold (0.23 log units), on the high side; the range from low to high includes it.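

In this assay, within the data shown here, thiophen-3-yl in place of pyridin-3-yl gives a 1.9-fold lower number from compound 2 to compound 3 (0.28 log units; within the scatter) as the first measured step at this position. The carbon next to the ring nitrogen therefore accepts a five-membered sulfur ring for a six-membered nitrogen ring with no change beyond the scatter. Nothing on hand explains this result.

On these data alone, whether an amine or a carboxylic acid on this carbon would give a step beyond the scatter remains open. So does whether the exchange behaves alike without the 4-chlorophenyl group.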